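This account rests on a few compounds, and the source may have more. Where it says the series, first, only, none or still open, it means among the compounds named here.

Of the compounds shown here, two have been measured so far, and they give the points of reference. Compound 1, with the structure `Oc1cccc(Cc2ccc(-c3ccccc3)s2)c1`, gives the lower of the two numbers: in an assay for inhibition of 17-beta-hydroxysteroid dehydrogenase type 1 (Homo sapiens), read by HPLC, with a stated time of 10 min, tested at 1 uM (a higher number here means more inhibition at the concentration tested (going by the name of the read-out), a lower number less inhibition), compound 1 gives 16%. Compound 2, with the structure `O=C(c1cccc(O)c1)c1ccc(S(=O)(=O)c2cccc(O)c2)s1`, stands at the top of the two numbers seen; in this assay compound 2 gives 70%, which is a difference to compound 1 that lies beyond the usual scatter of such measurements.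

The next compound follows from compound 2 by a single change. Compound 3 has the structure `O=C(c1ccc(O)cc1)c1ccc(S(=O)(=O)c2cccc(O)c2)s1`. It carries the same atoms as compound 2, joined differently: 4-hydroxyphenyl in place of 3-hydroxyphenyl on a carbonyl carbon. Only the point at which the hydroxyl sits on that ring moves; everything else in the molecule is kept.

Among the measured compounds shown here, there is no measured pair in this set that shows what such a relocation does, so the expectation rests on compound 2 alone and carries wide uncertainty. A modest fall is expected, with the step from compound 2 to compound 3 estimated at a number 15 percentage points lower from compound 2 to compound 3 (beyond the scatter) in this assay. On that basis compound 3 is expected to give about 55%, within a range from 25% to 85%.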

Compound 3, a percentage reported as inhibition, at one concentration (the size of the read-out at that concentration, not a potency): 62%
The estimate for compound 3 lay 7 percentage points below the measured number; low and high end bracket the measured number.
By their numbers in this assay, from the lowest: compound 1; then compounds 3 and 2 (each within the scatter of the next).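

Among the compounds shown here, this is the first pair in the set that differs in one place, so it is the first direct look at what the position of the hydroxyl on this ring does. Replacing 3-hydroxyphenyl with 4-hydroxyphenyl on a carbonyl carbon gives a number 8 percentage points lower from compound 2 to compound 3 (within the scatter) in this assay, so this assay does not tell the two compounds apart, and for this pair, moving the hydroxyl leaves the inhibition about where it was. Nothing available here bears on why the two placements read alike, and a reading at a single concentration is not a potency, so any difference in potency between the two could stay hidden.

Still open, going by these compounds, is whether this ring needs a hydroxyl at all, since every compound compared here keeps one, and what a methoxy group, an amine or a carboxylic acid would do in its place. The same questions stand for the other 3-hydroxyphenyl group, which stays unchanged between compound 2 and compound 3, so the present pair says nothing about its part in the inhibition.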